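The compounds below may be only part of what the source reports. "The series", "measured", "known", "first", "only" and "open" are said of these compounds alone.

Compound 1 `O=C(Nc1ccc([N+](=O)[O-])cc1)c1cc(F)ccc1O` gives 1100 nM
Compound 2 `N#Cc1ccc(NC(=O)c2cc(Cl)ccc2O)cc1` gives 1860 nM
Compound 3 `N#Cc1ccc(NC(=O)c2ccccc2O)cc1` gives 5370 nM

These three compounds were measured in a functional assay on KG-1 cells (Homo sapiens) for cytotoxicity, read by luminescence and CellTiter-Glo, with a stated time of 3 days; a lower number here means a stronger inhibitor, a higher number a weaker inhibitor. Compound 3 and compound 2 share a core and differ in one place: chloro in place of hydrogen on an aromatic carbon. That change gave a 2.9-fold lower number from compound 3 to compound 2 (0.46 log units; beyond the scatter). Compound 1 has the lowest of the three numbers, but compound 2 lies within the scatter of it, so no order between compound 1 and compound 2 is claimed; compound 3 stands beyond the scatter from compound 1. The difference between the core of compound 1 and the core of compound 3 is not broken down here.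

Compound 4 `O=C(Nc1ccc([N+](=O)[O-])cc1Cl)c1cc(F)ccc1O` is not yet measured in this assay. It differs from compound 1 in one place: chloro in place of hydrogen on an aromatic carbon. Among the compounds with values here, this is the same kind of change as the one from compound 3 to compound 2, yet not the same: in compound 2 the chloro sits meta to a large group and para to a hydroxy group, while in compound 4 it sits ortho to a large group and meta to a nitro group, on the other ring of the core. Within the data shown here, the earlier step is the only guide available, and it comes from a different ring, so the expectation for compound 4 is held more loosely. Compound 4 is expected to show a 1.6-fold lower number from compound 1 to compound 4 (0.20 log units; within the scatter), a step leaning the same way as the earlier one because of a 2.9-fold lower number from compound 3 to compound 2 (0.46 log units; beyond the scatter) but smaller. The estimate for compound 4 in this assay is 700 nM, with a range from 250 nM to 2000 nM.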

Compound 4, half-maximal inhibitory concentration: 490 nM
Compound 4: the middle estimate sits 1.4-fold (0.15 log units) above what was measured; the range from low to high includes it.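

In this assay, chloro in place of hydrogen on an aromatic carbon gave a 2.2-fold lower number from compound 1 to compound 4 (0.35 log units; beyond the scatter), and the step can be set beside the one seen earlier on another core: the same change on two cores in this assay, a 2.9-fold lower number (0.46 log units; beyond the scatter) from compound 3 to compound 2 and a 2.2-fold lower number (0.35 log units; beyond the scatter) from compound 1 to compound 4, 1.3-fold (0.11 log units) apart, within the scatter of two such steps

Within these two pairs, then, the change carried over: the number fell on both cores, each step lay beyond the scatter, and the two steps cannot be told apart in size. This does not show that the change would behave the same way on every core in the series, since it rests on two pairs only, the chloro stands on a different ring of the core in each pair, and a cell read-out of cytotoxicity says nothing on why the number fell.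

The compounds shown leave open whether a bromo group, a methyl group or a methoxy group in the place of the chloro in compound 4 would move the number in the same direction and by a similar step. They also leave open how far the step would hold if the nitro group of compound 4 gave way to a carboxylic acid or an amine, or if chloro entered elsewhere on the same ring.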